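A Third Aryl Ether at the Limit of the Assay

A few compounds are considered here, and "the series" means these few. Any claim that something is new, unique, unknown or untested is made for them only; others in the source may bear on it.

- Compound 1 `COc1cc(OC)c(/C=C/C(=O)/C=C/c2cc3ccccc3nc2Oc2ccc(Br)cc2)c(OC)c1` gives > 10000 nM as a limit
- Compound 2 `COc1cc(OC)c(/C=C/C(=O)/C=C/c2cc3ccccc3nc2Oc2cccc(Cl)c2)c(OC)c1` gives > 10000 nM as a limit

In a functional assay on PC-3 cells (Homo sapiens) for cytotoxicity, read by MTT assay, with a stated time of 48 h (on this read-out lower numbers stand for stronger inhibition and higher numbers for weaker inhibition), compound 2 gives > 10000 nM and this is a limit, not a number. All that has been read so far is the limit of > 10000 nM in this assay, at which 2 of the 2 values shown sit, with no true number yet.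

Compound 3 `COc1cc(OC)c(/C=C/C(=O)/C=C/c2cc3ccccc3nc2Oc2ccccc2C(C)C)c(OC)c1` changes one group: 2-isopropylphenyl in place of 3-chlorophenyl on an oxygen on an aromatic ring ( 2-isopropylphenyl in place of 3-chlorophenyl on an oxygen on an aromatic ring ). Among the measured compounds shown here, the only measured step bearing on this change is a step that the two limits leave unreadable from compound 1 to compound 2 and it gives no size to carry over. The expected move is a step that the limit leaves unreadable from compound 2 to compound 3 with no clear direction and nothing expected beyond the scatter. Compound 3 is estimated at 12000 nM with 3000 nM to 30000 nM as its expected range.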

Compound 3, half-maximal inhibitory concentration: > 10000 nM
Compound 3 was reported as a limit; the forecaster's own chance of this, stated with the estimate: 75%; the middle value lies beyond the limit too.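

In this assay, among the compounds shown here, compound 1, compound 2 and compound 3 each give a limit, not a number, so no step between them can be read: the limit of > 10000 nM in this assay, at which 3 of the 3 values shown sit.
Going by these compounds, how strongly each compound acts on these cells, and whether the group on the oxygen matters at all, stays open.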